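The source may report more compounds than this note shows. Statements on the series, on what has been measured and on what is new or still open speak of the compounds shown alone.

Three compounds share a benzamide built on an aniline that carries a sulfonamide and a benzyl ether, and they were tested in a functional assay on SK-BR-3 cells (Homo sapiens) for antiproliferative activity, read by MTT assay, with a stated time of 48 h; a lower number here means a stronger inhibitor, a higher number a weaker inhibitor. Compound 1 `COc1ccc(C(=O)Nc2ccc(N(C)S(C)(=O)=O)c(OCc3cc(C(F)(F)F)ccc3C)c2)cc1OC` gives 16900 nM in this assay. Compound 2 `Cc1ccc(C(F)(F)F)cc1COc1cc(NC(=O)c2ccc(I)cc2)ccc1N(C)S(C)(=O)=O` differs from compound 1 only in the group on the carbonyl carbon; in this assay compound 2 gives 3500 nM. That one change is 4-iodophenyl in place of 3,4-dimethoxyphenyl on a carbonyl carbon and it made a step of a 4.8-fold lower number from compound 1 to compound 2 (0.68 log units; beyond the scatter). Compound 3 `COc1ccc(OC)c(COc2cc(NC(=O)c3ccc(OC)c(OC)c3)ccc2NS(C)(=O)=O)c1` rests on a different core; how its core differs from the core of compound 1 is not broken down here. In this assay compound 3 gives 11 nM, the lowest of the three numbers, and its gap to compound 2 lies beyond the scatter.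

Compound 4 `COc1ccc(OC)c(COc2cc(NC(=O)c3ccc(I)cc3)ccc2NS(C)(=O)=O)c1` has not yet been measured. Among the measured compounds shown here, it is made from compound 3 by 4-iodophenyl in place of 3,4-dimethoxyphenyl on a carbonyl carbon, which is the same change as the one from compound 1 to compound 2, at the same place. For the measured compounds named here, a step of a 2.2-fold lower number from compound 3 to compound 4 (0.34 log units; beyond the scatter) is expected, smaller than the earlier one, because compound 3 already stands at 11 nM and only a single earlier example carries the change. Compound 4 is therefore estimated at 5 nM, likely between 1.5 nM and 20 nM.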

Compound 4, half-maximal inhibitory concentration: 11.8 nM
Compound 4: the middle estimate sits 2.4-fold (0.37 log units) below what was measured; the range from low to high includes it.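

In this assay, placing 4-iodophenyl where 3,4-dimethoxyphenyl stood on the carbonyl carbon gave a 1.1-fold higher number from compound 3 to compound 4 (0.03 log units; within the scatter), so on this core the swap produced no readable change. The same swap therefore did not carry over from one core to the other with the same size of step: the same change on two cores in this assay, a 4.8-fold lower number (0.68 log units; beyond the scatter) from compound 1 to compound 2 and a 1.1-fold higher number (0.03 log units; within the scatter) from compound 3 to compound 4, 5.2-fold (0.71 log units) apart, beyond the scatter of two such steps. Among the compounds shown here, this shows that a step seen on the core of compound 1 cannot simply be added to another core, but with only two pairs it does not show what sets the two steps apart, or how the swap would behave on a third core.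

The compounds shown leave open which difference between the two cores matters, the methyl on the sulfonamide nitrogen or the groups on the benzyl ether. They also leave open how a 4-bromophenyl or a 4-aminophenyl group on the same carbonyl carbon would fare on either core.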